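This account rests on a few compounds, and the source may have more. Where it says the series, first, only, none or still open, it means among the compounds named here.

Measured so far:
Compound 1, `Cc1cc(C(=O)O)ccc1OC[C@H](C)COc1ccc(C(=O)CC(C)(C)C)c(O)c1C`: in an assay for positive allosteric modulation of metabotropic glutamate receptor 3 (Rattus norvegicus) (a lower number here means that less compound is needed, a higher number that more compound is needed for the effect), compound 1 gives 1520 nM.
Compound 2, `Cc1cc(OC[C@H](C)COc2ccc(C(=O)CC(C)(C)C)c(O)c2C)ccc1C(=O)O`: in this assay compound 2 gives 1350 nM.

For the measured compounds named here, compound 2 holds the lower of the two numbers, but its only neighbour is compound 1, and a 1.1-fold lower number from compound 1 to compound 2 (0.05 log units; within the scatter), so the two cannot be ordered.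

Compound 3, `Cc1c(OC[C@@H](C)COc2ccc3c(c2)C(=O)NC3)ccc(C(=O)CC(C)(C)C)c1O`, is not yet measured. It differs from compound 2 in that (a group of 10 heavy atoms (8 carbon, 1 nitrogen, 1 oxygen; one five-membered non-aromatic ring with 1 hetero atom, one six-membered aromatic ring of carbon only) in place of a group of 10 heavy atoms (8 carbon, 2 oxygen; one six-membered aromatic ring of carbon only), on an oxygen on a saturated carbon). Going by the values given here, the single measured step, a 1.1-fold lower number from compound 1 to compound 2 (0.05 log units; within the scatter), exchanges one carboxy-methylphenyl for another and keeps the carboxylic acid in place; no measured pair exchanges the acid-bearing group for the entering group. That step therefore does not bear on the change to compound 3, and no direction can be read from the data. The expected step, a 1.1-fold higher number from compound 2 to compound 3 (0.05 log units; within the scatter), is set at nothing beyond the scatter, with a wide range to reflect the missing precedent. Compound 3 is estimated at 1500 nM in this assay, between 400 nM and 6000 nM.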

Compound 3, half-maximal effective concentration: "not active" (no number reported)
Compound 3: no number reported; the estimate stays without a comparison.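

For the compounds shown here, compound 3 is reported as "not active" in this assay without a number, so no step from compound 2 to compound 3 can be read. Nothing available accounts for this result. The compounds shown leave open whether any group without the carboxy function gives a measurable number.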